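A few compounds are considered here, and "the series" means these few. Any claim that something is new, unique, unknown or untested is made for them only; others in the source may bear on it.

Measured compounds:
compound 1 `Cn1nccc1-c1cc(C(F)(F)F)ccc1[C@H]1CCc2cc(S(=O)(=O)Nc3ncccn3)ccc21`: 3950 ng.h/mL
compound 2 `O=S(=O)(Nc1ncccn1)c1ccc2c(c1)OCC[C@@H]2c1ccc(C(F)(F)F)cc1-c1ccc(F)nc1`: 7960 ng.h/mL

Within the data shown here, in an ADME assay on the whole organism (Rattus norvegicus, strain Sprague-Dawley), read by LC-MS, with a stated time of 24 h, at a dose of 1 mg/kg by the intravenous route (on this read-out higher numbers stand for higher exposure at the dose given and lower numbers for lower exposure), compound 2 gives 7960 ng.h/mL, the higher of the two numbers measured so far; its nearest neighbour on this read-out is compound 1, which in this assay gives 3950 ng.h/mL, and the gap between the two lies within the usual scatter, so no order can be read from them. Among the measured compounds shown here, compound 1 and compound 2 differ from each other in two places, and no single step between measured compounds is available.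

Compound 3 `Cn1nccc1-c1cc(C(F)(F)F)ccc1[C@H]1CCOc2cc(S(=O)(=O)Nc3ncccn3)ccc21` has not yet been measured. It differs from compound 2 in one place: 1-methyl-1H-pyrazol-5-yl in place of 6-fluoropyridin-3-yl on an aromatic carbon. The same 1-methyl-1H-pyrazol-5-yl group is present in compound 1, on a different core, where compound 1 gives 3950 ng.h/mL in this assay.

With the two measured values within the scatter of each other, the step from compound 2 to compound 3 in this assay is expected to be a 1.7-fold lower number from compound 2 to compound 3 (0.22 log units; within the scatter), a change of no great size in either direction. Compound 3 is therefore expected to give about 4800 ng.h/mL in this assay, with a range from 2000 ng.h/mL to 11000 ng.h/mL.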

Compound 3, area under the concentration-time curve: 5670 ng.h/mL
Compound 3: middle estimate off by 1.2-fold (0.07 log units), on the low side; measured number inside the range.
By their numbers in this assay, from the lowest: compounds 1, 3 and 2 (each within the scatter of the next).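

In this assay, among these compounds, the exchange of 6-fluoropyridin-3-yl for 1-methyl-1H-pyrazol-5-yl, on an aromatic carbon ortho to a large group and meta to a trifluoromethyl group, gives a 1.4-fold lower number from compound 2 to compound 3 (0.15 log units; within the scatter), and this is the first comparison that isolates this position, since compound 1 and compound 2 differ in two places. On the shared core, then, a six-membered aromatic ring with one hetero atom and a five-membered aromatic ring with two hetero atoms cannot be told apart on this read-out. Nothing available bears on why the two groups sit so close.

The compounds shown leave open whether this holds beyond two aromatic rings: an amine, a carboxylic acid or a simple chain of carbon atoms on the same aromatic carbon could still move the number beyond the scatter. They also leave open whether 6-fluoropyridin-3-yl and 1-methyl-1H-pyrazol-5-yl would stay as close on the core of compound 1, and a single pair on a single read-out cannot settle that.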